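Moving a Trifluoromethyl Group Around the Ring

The compounds below may be only part of what the source reports. "The series", "measured", "known", "first", "only" and "open" are said of these compounds alone.

Three compounds built on a shared core were tested in a functional assay on A549 cells (Homo sapiens) for inhibition, read by MTT assay, with a stated time of 72 h; on this read-out higher numbers stand for weaker inhibition and lower numbers for stronger inhibition. Compound 1, `CN(C(=O)NC(=O)c1cccc(C(F)(F)F)c1)c1nc(C(F)(F)F)c(C(=O)N/N=C/c2cccc(C(F)(F)F)c2)s1`, gives 8.16 ug/mL in this assay. Compound 3, `CN(C(=O)NC(=O)c1ccc(F)c(F)c1)c1nc(C(F)(F)F)c(C(=O)N/N=C/c2ccc([N+](=O)[O-])cc2)s1`, gives 5.78 ug/mL in this assay. Compound 2, `Cc1nc(N(C)C(=O)NC(=O)c2c(F)cccc2F)sc1C(=O)N/N=C/c1ccc(C(F)(F)F)cc1`, gives 60.5 ug/mL in this assay, which is the highest of the three numbers, so compound 2 is the weakest inhibitor of the three: its nearest neighbour on the scale is compound 1 and its furthest is compound 3, and both of those gaps lie beyond the usual scatter of repeated measurements.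

Compound 4, `Cc1nc(N(C)C(=O)NC(=O)c2c(F)cccc2F)sc1C(=O)N/N=C/c1ccccc1C(F)(F)F`, has not yet been measured. Among the measured compounds shown here, it contains the same atoms as compound 2, joined differently, and the single change is 2-(trifluoromethyl)phenyl in place of 4-(trifluoromethyl)phenyl on a carbon with a double bond to nitrogen.

For the measured compounds named here, no measured pair of compounds shows what this kind of change does to the read-out, so the expectation for compound 4 can rest only on the value of compound 2 itself. With nothing to point in either direction, the step from compound 2 to compound 4 is expected to be small, a 1.2-fold lower number from compound 2 to compound 4 (0.08 log units; within the scatter), most likely within the scatter. Compound 4 is therefore expected to give about 50 ug/mL in this assay, with a range from 20 ug/mL to 150 ug/mL.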

Compound 4, half-maximal inhibitory concentration: 5.43 ug/mL
The estimate for compound 4 lay 9.2-fold (0.96 log units) above the measured number, outside the stated range (below it).
By their numbers in this assay, from the lowest: compounds 4, 3 and 1 (each within the scatter of the next); then compound 2.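

Where the trifluoromethyl group sits on this phenyl ring matters a great deal in this assay: 2-(trifluoromethyl)phenyl in place of 4-(trifluoromethyl)phenyl, on a carbon with a double bond to nitrogen, gives an 11-fold lower number from compound 2 to compound 4 (1.05 log units; beyond the scatter). Among the compounds shown here, until this pair, no measured step said anything about this position, and it now proves sensitive to a change that adds and removes no atom, since the group that leaves and the group that enters have the same atoms and differ only in how they are joined. The numbers show how large the step is, but nothing available here explains it.

This single pair leaves open whether the step belongs to the trifluoromethyl group itself or would also appear if another group, such as a methoxy group or an amine, were moved in the same way on this ring. It also leaves open whether the same change would have a similar effect on a compound that differs from compound 2 elsewhere in the molecule.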